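Dimethylamino in place of anilino on the shared core

The source may report more compounds than this note shows. Statements on the series, on what has been measured and on what is new or still open speak of the compounds shown alone.

Measured compounds:
- Compound 1 `CSc1[nH]ccc2ncnc1-2`: 4%
- Compound 2 `OC[C@H]1OC(n2cnc3c(SCc4ccccc4)nccc32)[C@H](O)[C@@H]1O`: 30%
- Compound 3 `OC[C@H]1OC(n2cnc3c(Nc4ccccc4)nccc32)[C@H](O)[C@@H]1O`: 4%

In a functional assay (Homo sapiens) for inhibition of Nucleic Acid, tested at 100 uM (a lower number here means less inhibition, a higher number more inhibition at the concentration tested (going by the name of the read-out)), compound 3 gives 4%, level with compound 1 at the digits shown and together the lowest of the three numbers; the only compound clearly apart is compound 2, which gives 30%. Within the data shown here, the one measured step with a single change, a number 26 percentage points lower from compound 2 to compound 3 (beyond the scatter), is the sole comparison of this kind available, and it concerns a different group.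

Compound 4 `CN(C)c1nccc2c1ncn2C1O[C@H](CO)[C@@H](O)[C@H]1O` differs from compound 3 as follows: dimethylamino in place of anilino on an aromatic carbon. Among the measured compounds shown here, no measured pair shows this exchange, so the step in this assay cannot be read from a precedent. Two of the three compounds sit at the low end, and the change is a small one on the same carbon, so little movement beyond the scatter is expected. Compound 4 is therefore expected to give about 6%, between 0% and 25%, which means an expected step of a number 2 percentage points higher from compound 3 to compound 4 (within the scatter).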

Compound 4, a percentage reported as inhibition, at one concentration (the size of the read-out at that concentration, not a potency): 0%
The estimate for compound 4 lay 6 percentage points above the measured number, within the range that was stated.
By their numbers in this assay, from the lowest: compounds 4, 1 and 3 (each within the scatter of the next); then compound 2.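

In this assay, replacing anilino with dimethylamino on this aromatic carbon gives a number 4 percentage points lower from compound 3 to compound 4 (within the scatter) and so removes the six-membered aromatic ring and the hydrogen-bond donor without a change that can be told from the scatter. Replacing benzylsulfanyl with dimethylamino gives a number 30 percentage points lower from compound 2 to compound 4 (beyond the scatter) and is the second exchange at this position, after anilino, to leave benzylsulfanyl clearly apart from the group that takes its place. Nothing measured here accounts for these numbers.

The compounds shown leave open whether the higher number of compound 2 goes with the sulfur atom that links its group or with the benzyl part. A benzylamino group on the same carbon of the shared core would help to separate the two.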